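Arylacrylic acids on an indole core: dimethoxy variant

A few compounds are considered here, and "the series" means these few. Any claim that something is new, unique, unknown or untested is made for them only; others in the source may bear on it.

Measured so far:
compound 1 `COc1cc(/C(=C\c2cn(C(C)=O)c3ccc(OCc4ccccc4)cc23)C(=O)O)cc(OC)c1OC` — 59600 nM
compound 2 `COc1ccc(Cn2cc(/C=C(/C(=O)O)c3ccccc3)c3cc(OCc4ccccc4)ccc32)cc1` — 38200 nM

In a functional assay on LNCaP cells (Homo sapiens) for cytotoxicity, read by MTT assay, with a stated time of 72 h (a higher number here means a weaker inhibitor, a lower number a stronger inhibitor), compound 1 gives 59600 nM, the higher of the two numbers; compound 2 gives 38200 nM, within the scatter of compound 1, so no order between them is claimed. Compound 3 `COc1ccc(OC)c(/C(=C\c2cn(C(C)=O)c3ccc(OCc4ccccc4)cc23)C(=O)O)c1` is not yet measured; it differs from compound 1 by 2,5-dimethoxyphenyl in place of 3,4,5-trimethoxyphenyl on a double-bonded chain carbon bound to a carbonyl carbon and a double-bonded chain carbon. For the measured compounds named here, no step between measured compounds covers this change, so the expected step of a 1.1-fold lower number from compound 1 to compound 3 (0.03 log units; within the scatter) is small, in no clear direction, and not beyond the scatter. Compound 3 is therefore estimated at 55000 nM, with a range from 20000 nM to 150000 nM.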

Compound 3, half-maximal inhibitory concentration: 44100 nM
For compound 3 the middle estimate is 1.2-fold (0.10 log units) above the measured one; the range from low to high includes it.
By their numbers in this assay, from the lowest: compounds 2, 3 and 1 (each within the scatter of the next).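

In this assay, for the compounds shown here, 2,5-dimethoxyphenyl in place of 3,4,5-trimethoxyphenyl on a double-bonded chain carbon bound to a carbonyl carbon and a double-bonded chain carbon gives a 1.4-fold lower number from compound 1 to compound 3 (0.13 log units; within the scatter) as the first one-place comparison. At this position, this exchange of one methoxy-bearing phenyl group for the other therefore produces no change beyond the scatter. No measurement on hand bears on the reason for this result. Still open, on these data alone, is whether a group of another kind at this position, such as an amine or a hydroxyl, would move the number beyond the scatter.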